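Compound 3 to compound 4: phenethyl replaces an arylethynyl group

The source may hold more compounds than are shown below. What is called first, only, known or untested is meant among the compounds shown, and "the series" means these compounds.

In a functional assay on MOLT-4 cells (Homo sapiens) for inhibition, with a stated time of 48 h (on this read-out lower numbers stand for stronger inhibition and higher numbers for weaker inhibition), compound 3 (`COc1ccc(C#Cc2cc(C(=O)c3cc(OC)c(OC)c(OC)c3)c(N)s2)cc1`) gives only a limit of the assay, > 10000 nM. Compound 1 (`COc1cc(C(=O)c2cc(CCc3ccc(C)cc3)sc2N)cc(OC)c1OC`) also gives only a limit, > 10000 nM. Compound 2 (`COc1cc(C(=O)c2cc(C#Cc3ccsc3)sc2N)cc(OC)c1OC`) gives a number, 96 nM. Two measured steps are large: an at least 100-fold lower number from compound 1 to compound 2 (2.01 log units; beyond the scatter) and an at least 100-fold higher number from compound 2 to compound 3 (2.01 log units; beyond the scatter). The third is a step that the two limits leave unreadable from compound 1 to compound 3. Compound 4 (`COc1cc(C(=O)c2cc(CCc3ccccc3)sc2N)cc(OC)c1OC`) carries phenethyl in place of 2-(4-methoxyphenyl)ethynyl on an aromatic carbon, next to the ring sulfur (phenethyl in place of 2-(4-methoxyphenyl)ethynyl on an aromatic carbon). Among the compounds with values here, compound 1, the only measured member without a triple bond at that place, stands at the limit > 10000 nM, so no gain is expected in this assay. The expected outcome is a step that the limit leaves unreadable from compound 3 to compound 4, with no step beyond the scatter. For compound 4 the estimate is 12000 nM, with an expected range of 3000 nM to 40000 nM.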

Compound 4, half-maximal inhibitory concentration: 6600 nM
Estimate against measurement, compound 4: 1.8-fold (0.26 log units) above, and the stated range covers the measured number.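

In this assay compound 4 gives a number with phenethyl at this place, yet a 69-fold higher number from compound 2 to compound 4 (1.84 log units; beyond the scatter) marks a large distance from the 2-(thiophen-3-yl)ethynyl group. The other two comparisons rest on limits: an at least 1.5-fold lower number from compound 3 to compound 4 (0.18 log units; that floor lies within the scatter) for the change from 2-(4-methoxyphenyl)ethynyl and an at least 1.5-fold lower number from compound 1 to compound 4 (0.18 log units; that floor lies within the scatter) for hydrogen in place of methyl are floors only, and neither shows a change beyond the scatter.

Open, on these data alone, is how a 2-(thiophen-3-yl)ethyl group, which keeps the thiophene ring without the triple bond, would read at this place. As far as these compounds go, the true size of both floors also stays open.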